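This account rests on a few compounds, and the source may have more. Where it says the series, first, only, none or still open, it means among the compounds named here.

In an ADME assay on HEK293 cells (Homo sapiens) for inhibition, read by MTT assay, with a stated time of 3 days (a lower number here means a stronger inhibitor, a higher number a weaker inhibitor), compound 1 `COc1ccc(/C=C\c2cc(OC)c(OC)c(OC)c2)cc1OCc1ccccc1` gives 15000 nM and compound 2 `COc1ccc(COc2cc(/C=C\c3cc(OC)c(OC)c(OC)c3)ccc2OC)cc1` gives 64000 nM. Compound 3 `COc1ccccc1/C=C/CCCOc1cc(/C=C\c2cc(OC)c(OC)c(OC)c2)ccc1OC` stands at > 400000 nM, which is a limit of the assay and not a number. Compound 4 `COc1cccc(/C=C/CCCOc2cc(/C=C\c3cc(OC)c(OC)c(OC)c3)ccc2OC)c1` differs from it by 3-methoxyphenyl in place of 2-methoxyphenyl on a double-bonded chain carbon bound to a double-bonded chain carbon, with 3-methoxyphenyl in place of 2-methoxyphenyl on a double-bonded chain carbon bound to a double-bonded chain carbon. The nearest measured changes are the two that introduce the 4-(2-methoxyphenyl)but-3-en-1-yl group, an at least 26-fold higher number from compound 1 to compound 3 (1.42 log units; beyond the scatter) and an at least 6.2-fold higher number from compound 2 to compound 3 (0.79 log units; beyond the scatter), while a modest 4.3-fold higher number from compound 1 to compound 2 (0.63 log units; beyond the scatter) shows that a single methoxy can shift the number. None of these tests the swap itself, so no step beyond the scatter is expected, and the expected step is an at least 1.3-fold lower number from compound 3 to compound 4 (0.12 log units; that floor lies within the scatter). For compound 4 the estimate is 300000 nM, within an expected range of 70000 nM to 600000 nM.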

Compound 4, half-maximal inhibitory concentration: 39000 nM
The estimate for compound 4 lay 7.7-fold (0.89 log units) above the measured number; the measured number lies below the stated range.
By their numbers in this assay, from the lowest: compound 1; then compounds 4 and 2 (each within the scatter of the next). At a limit, above all of these: compound 3.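

Moving the methoxy from 2-methoxyphenyl to 3-methoxyphenyl, with the same atoms joined differently, gives an at least 10-fold lower number from compound 3 to compound 4 (1.01 log units; beyond the scatter) in this assay, so the earlier compounds' penalty for the butenyl group belonged to the 2-methoxyphenyl form and not to the chain as such. The figure for compound 3 is a limit and not a number: the limit of > 400000 nM in this assay, at which 1 of the 4 values shown sits. Against 4-methoxyphenyl, the 4-(3-methoxyphenyl)but-3-en-1-yl group gives a 1.6-fold lower number from compound 2 to compound 4 (0.22 log units; within the scatter), while against phenyl it gives a 2.6-fold higher number from compound 1 to compound 4 (0.41 log units; beyond the scatter).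

The compounds shown leave open how 4-(4-methoxyphenyl)but-3-en-1-yl, or an amine in place of the methoxy, would read.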